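The compounds below may be only part of what the source reports. "The series", "measured", "known", "first", "only" and "open" are said of these compounds alone.

Compound 2 `CC(=O)Nc1nc(-c2ccccc2)nc2nc(C)cn12` gives 231 nM in an assay on cell membranes for displacement of a labelled ligand from adenosine receptor A3 (Homo sapiens), in the presence of a further agent that is not named here (on this read-out lower numbers stand for stronger inhibition and higher numbers for weaker inhibition), the lowest of the two numbers recorded, ahead of compound 1 `Cc1cn2c(NC3CCCC3)nc(-c3ccccc3)nc2n1`, which gives 2250 nM. Among the compounds with values here, the one measured step, a 9.7-fold lower number from compound 1 to compound 2 (0.99 log units; beyond the scatter), is the only one that bears on the change to compound 3 `CC(=O)CNc1nc(-c2ccccc2)nc2nc(C)cn12`, namely (2-oxopropyl in place of acetyl on a nitrogen on an aromatic ring). The new group keeps the carbonyl but places an alkyl carbon on the ring nitrogen, as in compound 1, so a move toward weaker binding is expected, smaller than that step. For compound 3 the estimated step is a 3.0-fold higher number from compound 2 to compound 3 (0.48 log units; beyond the scatter). Compound 3 is thus expected to give 700 nM, within 200 nM to 2500 nM.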

Compound 3, inhibition constant: > 10000 nM
Compound 3 was reported as a limit (the forecaster's own chance of this, stated with the estimate: 5%); middle value at least 14-fold (1.15 log units) away from the limit.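

In this assay compound 3 gives > 10000 nM, which is a limit of the assay. Going from acetamido to (2-oxopropyl)amino gives an at least 43-fold higher number from compound 2 to compound 3 (1.63 log units; beyond the scatter), so at this nitrogen on an aromatic ring the carbonyl alone does not keep the number of the acetyl compound. The 2-oxopropyl group also falls behind cyclopentyl, with an at least 4.4-fold higher number from compound 1 to compound 3 (0.64 log units; beyond the scatter), so a carbonyl in the chain does not help here. The compounds shown leave open whether a longer acyl chain such as propanoyl, or a benzoyl group, on this nitrogen would match or improve on acetyl.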